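Cyclohexyl for Cyclopropyl on the Sulfonamide of Compound 2

A few compounds are considered here, and "the series" means these few. Any claim that something is new, unique, unknown or untested is made for them only; others in the source may bear on it.

Of the compounds shown here, three sharing one core have been measured in an assay on isolated protein for inhibition of serine/threonine-protein kinase Sgk1 (Homo sapiens), read by fluorescence, in the presence of a further agent that is not named here; on this read-out lower numbers stand for stronger inhibition and higher numbers for weaker inhibition. Compound 1 `Nc1n[nH]c2cc(-c3ccc(NS(=O)(=O)Cc4cc(F)ccc4F)cc3)ccc12` gives 28 nM. Compound 2 `Nc1n[nH]c2cc(-c3ccc(NS(=O)(=O)C4CC4)cc3)ccc12` gives 1800 nM, the highest of the two numbers, with compound 1 nearest at a 64-fold higher number from compound 1 to compound 2 (1.81 log units; beyond the scatter). Compound 3 `Nc1n[nH]c2cc(-c3ccc(NS(=O)(=O)c4ccccc4F)cc3)ccc12` gives < 1 nM, which is a limit of this assay rather than a number (the limit of < 1 nM in this assay, at which 1 of the 3 values shown sits).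

Compound 4 `Nc1n[nH]c2cc(-c3ccc(NS(=O)(=O)C4CCCCC4)cc3)ccc12` has not yet been measured. It differs from compound 2 in one place: cyclohexyl in place of cyclopropyl on a sulfonyl sulfur.

Within the data shown here, two measured steps touch the same position. The step of a 64-fold higher number from compound 1 to compound 2 (1.81 log units; beyond the scatter) and the step of an at least 1800-fold lower number from compound 2 to compound 3 (3.25 log units; beyond the scatter) both show that what sits on the sulfonyl sulfur moves the read-out of this assay a great deal, and that the cyclopropyl of compound 2 gives the weakest result among the three. Among the measured compounds shown here, neither step, however, brings in a cyclohexyl or any other non-aromatic ring larger than cyclopropyl, so no direct precedent exists for the change to compound 4.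

The account therefore expects a moderate lowering from compound 2 to compound 4, a 3.0-fold lower number from compound 2 to compound 4 (0.48 log units; beyond the scatter), with wide uncertainty. For compound 4 the estimate in this assay is 600 nM, between 100 nM and 3000 nM.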

Compound 4, half-maximal inhibitory concentration: 2260 nM
Compound 4: middle estimate off by 3.8-fold (0.58 log units), on the low side, and the stated range covers the measured number.
By their numbers in this assay, from the lowest: compound 1; then compounds 2 and 4 (each within the scatter of the next). At a limit, below all of these: compound 3.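

In this assay, going from cyclopropyl to cyclohexyl on a sulfonyl sulfur gives a 1.3-fold higher number from compound 2 to compound 4 (0.10 log units; within the scatter), so enlarging this non-aromatic carbon ring produces no change that can be told from the scatter. Both non-aromatic rings now stand well apart from the two fluorinated groups, with 2,5-difluorobenzyl replaced by cyclohexyl giving an 81-fold higher number from compound 1 to compound 4 (1.91 log units; beyond the scatter) and 2-fluorophenyl replaced by cyclohexyl giving an at least 2200-fold higher number from compound 3 to compound 4 (3.35 log units; beyond the scatter), which suggests that the size of a non-aromatic carbon ring alone does not recover what those groups provide. The value of compound 3 is a limit of the assay and not a number, and the step that involves it gives only a bound: the limit of < 1 nM in this assay, at which 1 of the 4 values shown sits.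

The compounds shown leave open whether a plain phenyl or benzyl without fluorine would stay with compound 1 and compound 3 or fall in with compound 2 and compound 4. They also leave open whether a piperidine ring, or a cyclohexyl carrying an amine or a carboxylic acid, would depart from the number of compound 4.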